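Swapping a chlorine for a methyl-and-trifluoromethyl pair

A few compounds are considered here, and "the series" means these few. Any claim that something is new, unique, unknown or untested is made for them only; others in the source may bear on it.

Compound 1 `CNC(=O)c1cccc(Cn2nc(C)c(NC(=O)c3ccc(COc4ccccc4Cl)cc3)c2C)c1`: 6300 nM
Compound 2 `CNC(=O)c1cccc(Cn2nc(C)c(NC(=O)c3ccc(COc4ccc(Cl)cc4)cc3)c2C)c1`: 4200 nM

Among the compounds with values here, in a functional assay on MIA PaCa-2 cells (Homo sapiens) for antiproliferative activity, read by MTT assay, with a stated time of 72 h (a lower number here means that less compound is needed, a higher number that more compound is needed for the effect), compound 2 gives the lowest of the two numbers, and the only measured step, a 1.5-fold lower number from compound 1 to compound 2 (0.18 log units; within the scatter), lies within the scatter. Compound 3 `CNC(=O)c1cccc(Cn2nc(C)c(NC(=O)c3ccc(COc4ccc(C(F)(F)F)cc4C)cc3)c2C)c1` differs from compound 2 by 2-methyl-4-(trifluoromethyl)phenyl in place of 4-chlorophenyl on an oxygen on a saturated carbon. Within the data shown here, that earlier step is the only one touching this ring, and it moved the number little; the entering group has no measured precedent here. The expected step is therefore small, a 1.4-fold lower number from compound 2 to compound 3 (0.15 log units; within the scatter), not clearly beyond the scatter. Compound 3 is expected at 3000 nM, with a range from 1000 nM to 9000 nM.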

Compound 3, half-maximal effective concentration: 620 nM
Compound 3: the middle estimate sits 4.8-fold (0.68 log units) above what was measured, and the stated range ends above it.
By their numbers in this assay, from the lowest: compound 3; then compounds 2 and 1 (each within the scatter of the next).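

In this assay, the group on this oxygen can clearly move the number: 2-methyl-4-(trifluoromethyl)phenyl gives a 6.8-fold lower number from compound 2 to compound 3 (0.83 log units; beyond the scatter) and a 10-fold lower number from compound 1 to compound 3 (1.01 log units; beyond the scatter). Within the data shown here, the earlier change from 2-chlorophenyl to 4-chlorophenyl stayed within the scatter, so only this larger swap shows that the position responds. Nothing available here explains the drop.

On these data alone, the entering group differs from 4-chlorophenyl in two ways at once, so it remains open whether 2-methylphenyl or 4-(trifluoromethyl)phenyl alone would give the same step. As far as these compounds go, how an amine or a carboxylic acid on this ring would behave also remains open.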